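The source may report more compounds than this note shows. Statements on the series, on what has been measured and on what is new or still open speak of the compounds shown alone.

Three close analogues share one core and differ only in the aryl group attached to the urea nitrogen. Compound 1 `COc1cc(NC(C)CCCNC(=O)Nc2cccc(Cl)c2)c2ncccc2c1` gives 21000 nM in a functional assay on MOLT-4 cells (Homo sapiens) for inhibition, read by MTT assay, with a stated time of 72 h; on this read-out higher numbers stand for weaker inhibition and lower numbers for stronger inhibition; compound 2 `COc1cc(NC(C)CCCNC(=O)Nc2ccc(F)cc2)c2ncccc2c1` gives 24000 nM, and compound 3 `COc1cc(NC(C)CCCNC(=O)Nc2cccc(O)c2)c2ncccc2c1` gives 24000 nM. Compound 1 has the lowest of the three numbers, yet the steps of a 1.1-fold higher number from compound 1 to compound 2 (0.06 log units; within the scatter) and a 1.1-fold higher number from compound 1 to compound 3 (0.06 log units; within the scatter) both lie within the scatter, as does no change at the digits printed from compound 2 to compound 3 (within the scatter), so the three compounds cannot be ranked on these data.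

Compound 4 `COc1cc(NC(C)CCCNC(=O)Nc2ccc(O)cc2)c2ncccc2c1` has not yet been measured. It differs from compound 1 by 4-hydroxyphenyl in place of 3-chlorophenyl on an amide-type nitrogen. The measured steps that bear on this change are the swap of the aryl ring from compound 1 to compound 2 and the exchange of chloro for hydroxy from compound 1 to compound 3, neither of which moved the number beyond the scatter. The expectation for compound 4 is therefore a step of a 1.1-fold higher number from compound 1 to compound 4 (0.06 log units; within the scatter), with no change beyond the scatter. Compound 4 is estimated at 24000 nM, within a range from 12000 nM to 48000 nM.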

Compound 4, half-maximal inhibitory concentration: 21000 nM
Beside the measured number, compound 4's estimate is 1.1-fold (0.06 log units) above it; low and high end bracket the measured number.
By their numbers in this assay, from the lowest: compounds 1, 4, 2 and 3 (each within the scatter of the next).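

In this assay the exchange of 3-chlorophenyl for 4-hydroxyphenyl on this amide-type nitrogen gives no change at the digits printed from compound 1 to compound 4 (within the scatter) and so shows that the number stays within the scatter even when a hydrogen-bond donor and acceptor enter where the leaving group has none. The other two new comparisons agree, with 4-hydroxyphenyl in place of 3-hydroxyphenyl giving a 1.1-fold lower number from compound 3 to compound 4 (0.06 log units; within the scatter) and the exchange of fluoro for hydroxy giving a 1.1-fold lower number from compound 2 to compound 4 (0.06 log units; within the scatter) and leaving all four aryl groups within the scatter of one another. No evidence is available on what lies behind this flat result.

From the compounds shown here alone, it remains open whether an amine or a carboxylic acid on the phenyl ring would move the number beyond the scatter. Going by these compounds, it also remains open whether a longer chain between the shared core and the urea would do so.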